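Amide variation on the shared core: hydroxy-neopentyl in place of lactam

A few compounds are considered here, and "the series" means these few. Any claim that something is new, unique, unknown or untested is made for them only; others in the source may bear on it.

Measured compounds:
- compound 1 `CC1Cc2c(sc(NC(=O)c3ccccc3O)c2C(N)=O)C(C)O1`: 4 nM
- compound 2 `CC1(C)Cc2c(sc(NC(=O)C3CCNC3=O)c2C(N)=O)C(C)(C)O1`: 101 nM

In an assay on cells for positive allosteric modulation of Cystic fibrosis transmembrane conductance regulator variant F508del (Homo sapiens), with stated times of 10 min and 7 s, in the presence of a further agent that is not named here (on this read-out lower numbers stand for an effect already at smaller amounts and higher numbers for an effect only at larger amounts of compound), compound 1 gives 4 nM. In this assay compound 2 gives 101 nM, the highest of the two numbers recorded; the gap between compound 1 and compound 2 lies beyond the scatter, but the two differ in more than one place, so no single step can be read from it.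

Compound 3 `CC1(C)Cc2c(sc(NC(=O)[C@H](O)C(C)(C)C)c2C(N)=O)C(C)(C)O1` keeps the core of compound 2 and changes only the amide substituent: 1-hydroxy-2,2-dimethylpropyl in place of 2-oxopyrrolidin-3-yl on a carbonyl carbon. Both the leaving and the entering group carry one donor and one acceptor as counted, the ring being exchanged for an open chain with a defined stereocentre.

Within the data shown here, no measured pair isolates this change, so the expectation rests on compound 2 alone. For compound 3 the step of a 1.7-fold lower number from compound 2 to compound 3 (0.23 log units; within the scatter) is expected to be small, at most a modest move toward lower numbers and possibly none beyond the scatter. Compound 3 is therefore expected to give about 60 nM in this assay, within a range of 15 nM to 250 nM.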

Compound 3, half-maximal effective concentration: 127 nM
Beside the measured number, compound 3's estimate is 2.1-fold (0.33 log units) below it; the measured number falls inside the stated range.
By their numbers in this assay, from the lowest: compound 1; then compounds 2 and 3 (each within the scatter of the next).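

In this assay, 1-hydroxy-2,2-dimethylpropyl in place of 2-oxopyrrolidin-3-yl on a carbonyl carbon gives a 1.3-fold higher number from compound 2 to compound 3 (0.10 log units; within the scatter), so on this read-out compound 2 and compound 3 cannot be told apart. This first single-place step in the series shows that, on the core of compound 2, this position accepts an open chain with a defined stereocentre in place of a five-membered non-aromatic ring, and that neither that ring nor its nitrogen is required to keep the number within the scatter. No measurement shown accounts for this match between the two groups.

Still open, from the compounds shown here alone, is whether the hydroxy group of the chain and its defined stereocentre matter, which the opposite stereoisomer of compound 3, or an amine or a carboxylic acid in place of that hydroxy group, would test. Also open, going by these compounds, is how much of the gap to compound 1 belongs to the amide substituent and how much to the remainder of the core, which would need the amide substituent of compound 1 on the core of compound 2.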